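This account rests on a few compounds, and the source may have more. Where it says the series, first, only, none or still open, it means among the compounds named here.

Measured compounds in an in vitro functional assay on HEK285-7 cells for antagonist activity at prostaglandin D2 receptor 2 (Homo sapiens), read by BRET and beta-arrestin recruitment; a lower number here means a stronger inhibitor, a higher number a weaker inhibitor:
- compound 1, `N#Cc1cc(-c2nc(C(c3ccc(F)cc3)c3ccc(F)cc3)sc2CC(=O)O)ccc1F`: 520 nM
- compound 2, `O=C(O)Cc1sc(C(c2ccc(F)cc2)c2ccc(F)cc2)nc1-c1ccnc(N2CCC2)c1`: compound 2 gives only a limit, > 100000 nM
- compound 3, `O=C(O)Cc1sc(C(c2ccc(F)cc2)c2ccc(F)cc2)nc1-c1ccnc(N2CCCC2)c1`: compound 3 gives only a limit, > 100000 nM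

Compound 3 stands at the limit of this assay; no number is known for it, only that it lies beyond the range read. Compound 2 sits at the same limit (the limit of > 100000 nM in this assay, at which 2 of the 3 values shown sit), so the step that the two limits leave unreadable from compound 2 to compound 3 cannot be read.

Compound 4, `NS(=O)(=O)c1cccc(-c2nc(C(c3ccc(F)cc3)c3ccc(F)cc3)sc2CC(=O)O)c1`, is not yet measured. The change from compound 3 is 3-sulfamoylphenyl in place of 2-(pyrrolidin-1-yl)pyridin-4-yl on an aromatic carbon.

Among the compounds with values here, the steps that bear on it run the other way: an at least 190-fold higher number from compound 1 to compound 2 (2.28 log units; beyond the scatter) and an at least 190-fold higher number from compound 1 to compound 3 (2.28 log units; beyond the scatter), both from a phenyl ring on the shared core to a pyridin-4-yl bearing a cyclic amine. Compound 4 returns to a phenyl ring on the same carbon, carrying a sulfamoyl group instead of the nitrile and fluorine of compound 1. A large drop in the number from compound 3 to compound 4 is therefore expected, an at least 66-fold lower number from compound 3 to compound 4 (1.82 log units; beyond the scatter), though its exact size cannot be read from a limit. Compound 4 is estimated at 1500 nM, within 200 nM to 20000 nM.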

Compound 4, half-maximal inhibitory concentration: 710 nM
For compound 4 the middle estimate is 2.1-fold (0.32 log units) above the measured one; the measured number falls inside the stated range.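

In this assay, a substituted phenyl ring on this aromatic carbon of the shared core holds up with a different substituent: a 1.4-fold higher number from compound 1 to compound 4 (0.14 log units; within the scatter), so 3-sulfamoylphenyl and 3-cyano-4-fluorophenyl cannot be told apart here. The gap to the pyridin-4-yl compounds bearing a cyclic amine also persists when the nitrile and fluorine are replaced by a sulfamoyl group: an at least 140-fold lower number from compound 3 to compound 4 (2.14 log units; beyond the scatter) and an at least 140-fold lower number from compound 2 to compound 4 (2.14 log units; beyond the scatter). Both of these steps start from a limit and not from a number: the limit of > 100000 nM in this assay, at which 2 of the 4 values shown sit.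

Still open, from the compounds shown here alone, is whether the loss follows the pyridine ring or the cyclic amine, which an unsubstituted pyridin-4-yl or a phenyl ring bearing pyrrolidin-1-yl would separate. Also open, going by these compounds, is what the sulfamoyl nitrogen contributes, which a methylsulfonyl group on the same phenyl ring would test.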